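Nitrophenyl in place of dimethoxyphenyl: outlook for compound 4

The compounds below may be only part of what the source reports. "The series", "measured", "known", "first", "only" and "open" are said of these compounds alone.

Compound 1 `COc1ccc(OC)c(/C=C/C(=O)Nc2cc3c(Nc4ccc(F)c(Cl)c4)ncnc3cc2O[C@H]2CCOC2)c1` in a functional assay on PC-3 cells (Homo sapiens) for cytotoxicity, read by MTT assay, with a stated time of 72 h (on this read-out higher numbers stand for weaker inhibition and lower numbers for stronger inhibition), gives 8730 nM. Of the three measured compounds it stands second highest. Its nearest neighbour, compound 3 `COc1ccc(/C=C/C(=O)Nc2cc3c(Nc4ccc(F)c(Cl)c4)ncnc3cc2O[C@H]2CCOC2)c(OC)c1OC`, gives 7670 nM, with a 1.1-fold lower number from compound 1 to compound 3 (0.06 log units; within the scatter). Compound 2 `COc1cc(/C=C/C(=O)Nc2cc3c(Nc4ccc(F)c(Cl)c4)ncnc3cc2O[C@H]2CCOC2)cc(OC)c1` gives 25600 nM, with a 2.9-fold higher number from compound 1 to compound 2 (0.47 log units; beyond the scatter). Between the other two the step is a 3.3-fold lower number from compound 2 to compound 3 (0.52 log units; beyond the scatter). Compound 4 `O=C(/C=C/c1ccccc1[N+](=O)[O-])Nc1cc2c(Nc3ccc(F)c(Cl)c3)ncnc2cc1O[C@H]1CCOC1` carries 2-nitrophenyl in place of 2,5-dimethoxyphenyl on a double-bonded chain carbon bound to a double-bonded chain carbon. The measured steps bear on it only loosely: each of them rearranges methoxy groups on the same ring, and none brings in a nitro group. Those steps were modest at most, so a modest shift in this assay is expected, its direction uncertain. Compound 4 is estimated at 12000 nM, with a range of 4000 nM to 36000 nM. That estimate corresponds to a 1.4-fold higher number from compound 1 to compound 4 (0.14 log units; within the scatter).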

Compound 4, half-maximal inhibitory concentration: 7760 nM
For compound 4 the middle estimate is 1.5-fold (0.19 log units) above the measured one; low and high end bracket the measured number.
By their numbers in this assay, from the lowest: compounds 3, 4 and 1 (each within the scatter of the next); then compound 2.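

Replacing the methoxy groups with a nitro group at this position leaves the number unresolved from those of two methoxy-bearing rings in this assay: 2-nitrophenyl matches 2,5-dimethoxyphenyl (a 1.1-fold lower number from compound 1 to compound 4 (0.05 log units; within the scatter)) and 2,3,4-trimethoxyphenyl (a 1.0-fold higher number from compound 3 to compound 4 (0.01 log units; within the scatter)). Only 3,5-dimethoxyphenyl stands apart (a 3.3-fold lower number from compound 2 to compound 4 (0.52 log units; beyond the scatter)), so methoxy groups are not needed for the lower numbers seen in this small set. No supporting measurement accounts for this result. The compounds shown leave open whether an amine or a carboxylic acid on this ring would read like 2-nitrophenyl.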